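A Chloro Step From a Limit Value

A few compounds are considered here, and "the series" means these few. Any claim that something is new, unique, unknown or untested is made for them only; others in the source may bear on it.

In a functional assay on SF-268 cells (Homo sapiens) for inhibition, read by sulforhodamine B assay, with a stated time of 48 h (on this read-out higher numbers stand for weaker inhibition of growth and lower numbers for stronger inhibition of growth), compound 1 (`O=C(Nc1cccc(-n2cc(-c3ccncc3)c(-c3ccc(Cl)c(O)c3)n2)c1)Nc1cccc(C(F)(F)F)c1`) gives 15800 nM as a measured number. Compound 2 (`COc1cc(-c2nn(-c3cccc(NC(=O)c4cccc(C(F)(F)F)c4)c3)cc2-c2ccncc2)ccc1Cl`) stands at > 50000 nM in this assay and this value is a limit of the assay. Compound 3 (`COc1cc(-c2nn(-c3cccc(NC(=O)c4ccc(Cl)c(C(F)(F)F)c4)c3)cc2-c2ccncc2)ccc1Cl`) differs from compound 2 in one place: chloro in place of hydrogen on an aromatic carbon turns the 3-(trifluoromethyl)phenyl into 4-chloro-3-(trifluoromethyl)phenyl, with chloro in place of hydrogen on an aromatic carbon, ortho to a trifluoromethyl group and para to a large group. Going by the values given here, no measured pair here isolates this change, so the expectation is a loose one. A modest move toward stronger inhibition of growth is expected, and the estimated step is an at least 1.5-fold lower number from compound 2 to compound 3 (0.18 log units; that floor lies within the scatter) in this assay as a tentative figure. For compound 3 the estimated value is 33000 nM with an expected range of 12000 nM to 60000 nM in this read-out.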

Compound 3, concentration for total growth inhibition: > 32500 nM
Compound 3 ended at the assay's limit; the forecaster's own chance of this, stated with the estimate: 50%; the middle value is on the limit's open side.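

In this assay compound 3 stands at > 32500 nM, which is a limit of the assay. Compound 2 also stands at a limit, and no step can be read between compound 2 and compound 3. On these data alone, whether chloro in place of hydrogen changes inhibition of growth at all remains open.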